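Trading an Allylamino Group for Diethylamino on a Benzotriazine Dioxide Core

A few compounds are considered here, and "the series" means these few. Any claim that something is new, unique, unknown or untested is made for them only; others in the source may bear on it.

Of the compounds shown here, two with the same core have been measured. Compound 1, `CCCCCCCCNc1n[n+]([O-])c2ccccc2[n+]1[O-]`, carries an octylamino group and in a functional assay on HepG2 cells (Homo sapiens) for cytotoxicity, read by MTT assay, with a stated time of 48 h (a lower number here means a stronger inhibitor, a higher number a weaker inhibitor), compound 1 gives 17400 nM. Compound 2, `C=CCNc1n[n+]([O-])c2ccccc2[n+]1[O-]`, carries an allylamino group instead. In this assay compound 2 reaches only the limit of the test, > 56000 nM. Because of the limit of > 56000 nM in this assay, at which 1 of the 2 values shown sits, the comparison between the two measured compounds can only be given as a bound: an at least 3.2-fold higher number from compound 1 to compound 2 (0.50 log units; beyond the scatter).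

Compound 3, `CCN(CC)c1n[n+]([O-])c2ccccc2[n+]1[O-]`, has not yet been measured. It differs from compound 2 in one place, (diethylamino in place of allylamino on an aromatic carbon). For the measured compounds named here, the only measured step concerns compound 1 and compound 2, and it shows that shortening the chain weakened the compound at least modestly. Going by the values given here, no measured step speaks to removing the hydrogen-bond donor. On that basis compound 3 is expected to remain weak, with a step that the limit leaves unreadable from compound 2 to compound 3, and its estimated value is 70000 nM, within a range from 25000 nM to 200000 nM.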

Compound 3, half-maximal inhibitory concentration: > 107000 nM
Compound 3: a limit, no number; the forecaster's own chance of this, stated with the estimate: 60%; at least 1.5-fold (0.18 log units) between middle value and limit.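

In this assay compound 3 gives > 107000 nM, which is a limit and not a number. For the compounds shown here, compound 2 also sits at a limit, and no step between compound 2 and compound 3 can be read. Going by these compounds, the true values of both compounds remain open, as does whether diethylamino in place of allylamino changes the result at all.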